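What a 3,4-dimethoxyphenyl group may do to clearance

This account rests on a few compounds, and the source may have more. Where it says the series, first, only, none or still open, it means among the compounds named here.

In an in vitro ADME assay on microsomes from liver (Homo sapiens) for metabolic stability (on this read-out lower numbers stand for slow clearance and higher numbers for fast clearance), compound 1 `COc1ccc(C(=O)N2CCC(=CC(=O)N[C@@H]3CCN(Cc4ccc5cc(F)ccc5c4)C3)CC2)cc1` gives 252 mL/min/kg. Compound 2 `O=C(C=C1CCN(C(=O)c2ccccc2O)CC1)N[C@@H]1CCN(Cc2ccc3cc(F)ccc3c2)C1` gives < 64 mL/min/kg, and this is a limit of the assay and not a number. Compound 2 therefore has no exact position on this scale, only that limit.

Compound 3 `COc1ccc(C(=O)N2CCC(=CC(=O)N[C@@H]3CCN(Cc4ccc5cc(F)ccc5c4)C3)CC2)cc1OC` has not been measured yet. It keeps the shared core of compound 2 and differs on a carbonyl carbon whose other neighbour is an amide-type nitrogen in a ring: 3,4-dimethoxyphenyl in place of 2-hydroxyphenyl on a carbonyl carbon. In short, 3,4-dimethoxyphenyl stands in place of 2-hydroxyphenyl.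

Within the data shown here, only one measured step bears on this change, the swap of 4-methoxyphenyl for 2-hydroxyphenyl at the same place: an at least 3.9-fold lower number from compound 1 to compound 2 (0.59 log units; beyond the scatter). It lies beyond the scatter, though a single step is thin evidence. The incoming group of compound 3 has more in common by name with the 4-methoxyphenyl of compound 1, which gives 252 mL/min/kg, so a rise in this assay that largely reverses that step is expected. The expected change is an at least 3.4-fold higher number from compound 2 to compound 3 (0.53 log units; beyond the scatter). For compound 3 the estimated clearance is 220 mL/min/kg, with an expected range from 100 mL/min/kg to 420 mL/min/kg.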

Compound 3, clearance: 246 mL/min/kg
Compound 3: middle estimate off by 1.1-fold (0.05 log units), on the low side; low and high end bracket the measured number.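

In this assay, putting 3,4-dimethoxyphenyl on this carbonyl carbon gives up the low clearance seen with 2-hydroxyphenyl, with an at least 3.8-fold higher number from compound 2 to compound 3 (0.58 log units; beyond the scatter). Compound 2 has only a limit and not an exact number, so this step has a lower bound but no exact size: the limit of < 64 mL/min/kg in this assay, at which 1 of the 3 values shown sits. The methoxy added to the aromatic ring of the 4-methoxyphenyl group leaves the read-out within the scatter, with a 1.0-fold lower number from compound 1 to compound 3 (0.01 log units; within the scatter), so among these three compounds the two methoxy-bearing groups sit together and the 2-hydroxyphenyl group alone stands apart.

Among these compounds, compound 2 is the only compound here with a hydroxy group, and it differs from the others in both the kind and the place of its ring substituent, so the data cannot say whether the hydroxy group itself or its place on the ring goes with the low clearance. The compounds shown also leave open what a plain phenyl ring, an aminophenyl group or a carboxylic acid on the ring would do at this carbonyl carbon.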